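Heteroaryl ether to carbon-linked pyridyl chain on the shared core

A few compounds are considered here, and "the series" means these few. Any claim that something is new, unique, unknown or untested is made for them only; others in the source may bear on it.

Compound 1 `O=C(COCc1ccccn1)N1CCN(c2ccc(Cl)cc2Cl)CC1` and compound 2 `O=C(COCc1cncs1)N1CCN(c2ccc(Cl)cc2Cl)CC1` share one core and differ only in the heteroaryl group on the saturated chain carbon bound to the oxygen. Among the measured compounds shown here, in a functional assay on HEK293 cells for positive allosteric modulation of metabotropic glutamate receptor 5 (Homo sapiens), read by FLIPR and calcium flux (on this read-out lower numbers stand for an effect already at smaller amounts and higher numbers for an effect only at larger amounts of compound), compound 1 gives 310 nM, and compound 2 gives 1280 nM, so compound 2 stands at the higher of the two numbers known so far; the single measured step of a 4.1-fold higher number from compound 1 to compound 2 (0.62 log units; beyond the scatter) is the only comparison available.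

Compound 3 `O=C(CCCc1ccncc1)N1CCN(c2ccc(Cl)cc2Cl)CC1` has not been measured. It differs from compound 2 by 2-(pyridin-4-yl)ethyl in place of (1,3-thiazol-5-yl)methoxy on a saturated chain carbon bound to a carbonyl carbon. For the measured compounds named here, this change brings back a six-membered ring with one nitrogen, as in compound 1, while the oxygen on the chain is gone and the chain is longer; no measured pair covers the loss of that oxygen or the longer chain. The step from compound 1 to compound 2 shows that exchanging the heteroaryl alone moved the number beyond the scatter, so a step of similar size back toward the number of compound 1 is expected, with the unexamined chain change widening the uncertainty. Compound 3 is expected at 600 nM, within 200 nM to 3000 nM, an expected step of a 2.1-fold lower number from compound 2 to compound 3 (0.33 log units; beyond the scatter).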

Compound 3, half-maximal effective concentration: 5300 nM
Beside the measured number, compound 3's estimate is 8.8-fold (0.95 log units) below it, and the stated range ends below it.
By their numbers in this assay, from the lowest: compound 1; then compound 2; then compound 3.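

In this assay, the exchange of (1,3-thiazol-5-yl)methoxy for 2-(pyridin-4-yl)ethyl on a saturated chain carbon bound to a carbonyl carbon gives a 4.1-fold higher number from compound 2 to compound 3 (0.62 log units; beyond the scatter), so regaining a six-membered aromatic ring with 1 hetero atom does not by itself bring the number back toward that of compound 1. Set against (pyridin-2-yl)methoxy, the same group gives a 17-fold higher number from compound 1 to compound 3 (1.23 log units; beyond the scatter), a large step that exceeds the modest 4.1-fold higher number from compound 1 to compound 2 (0.62 log units; beyond the scatter) and shows that this place can move the number further than the heteroaryl exchange alone had shown. The ring, its point of attachment and the chain all differ at once in this change, and nothing measured here accounts for the rise.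

Still open, as far as these compounds go, is whether a (pyridin-4-yl)methoxy group or a 2-(pyridin-2-yl)ethyl group at this place would lie nearer compound 1 or compound 3, which would separate the chain oxygen from the ring attachment. Also open, from the compounds shown here alone, is how an amine nitrogen in place of the chain oxygen, or a shorter chain carrying the same pyridin-4-yl ring, would read out.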